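Thiourea series, maximal electroshock: methyl to 4-methylphenyl

The compounds below may be only part of what the source reports. "The series", "measured", "known", "first", "only" and "open" are said of these compounds alone.

Two compounds have so far been run in a functional assay on the whole organism with Mus musculus as the target, in the maximal electroshock model, with a stated time of 0.5 h; on this read-out lower numbers stand for an effect already at smaller amounts and higher numbers for an effect only at larger amounts of compound. Compound 1 `COc1cc(/C=N/NC(=O)Nc2ccc(Br)cc2)ccc1O` gives 300 mg/kg in this assay. Compound 2 `CNC(=S)Nc1ccc(S(=O)(=O)Nc2ccc(Cl)cc2)cc1` gives 300 mg/kg in this assay, level with compound 1 at the digits recorded, the two values lying within the scatter of each other. The next compound, compound 3 `Cc1ccc(NC(=S)Nc2ccc(S(=O)(=O)Nc3ccc(Cl)cc3)cc2)cc1`, is not yet measured in this assay. It differs from compound 2 in one place: 4-methylphenyl in place of methyl on an amide-type nitrogen. For the measured compounds named here, no step between measured compounds is available for this kind of change, and the two values in hand are indistinguishable, so there is nothing that points in either direction. The step from compound 2 to compound 3 is therefore expected to be no change at the digits printed from compound 2 to compound 3 (within the scatter), that is, none beyond the scatter. Compound 3 is accordingly estimated at 300 mg/kg in this assay, with a range from 100 mg/kg to 600 mg/kg; an outcome reported only as a limit of the assay cannot be excluded.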

Compound 3, minimum effective dose: 100 mg/kg
For compound 3 the middle estimate is 3.0-fold (0.48 log units) above the measured one, within the range that was stated.
By their numbers in this assay, from the lowest: compound 3; then compounds 1 and 2 (each within the scatter of the next).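

In this assay, for the compounds shown here, 4-methylphenyl in place of methyl on the amide-type nitrogen gives a 3.0-fold lower number from compound 2 to compound 3 (0.48 log units; beyond the scatter) and is the only step that can be read so far. It shows that this position is not indifferent to the group it carries, and that a six-membered aromatic ring of carbon only is tolerated there with no loss on this read-out. Nothing at hand bears on why the step occurs.

The compounds shown leave open whether the step belongs to the ring, to its methyl, or simply to a larger carbon group; plain phenyl, cyclohexyl or a longer chain such as butyl on the same nitrogen would separate these. As far as these compounds go, it also remains open how an amine or a carboxylic acid on that ring would read, and a single step supports no wider pattern.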